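The source may report more compounds than this note shows. Statements on the series, on what has been measured and on what is new or still open speak of the compounds shown alone.

Measured compounds:
compound 1 `CCCCN(CC)c1nc(C)nc2c1nnn2-c1c(C)cc(C)nc1C`: 65 nM
compound 2 `CCC(CC)Nc1nc(C)nc2c1nnn2-c1c(C)cc(C)cc1C`: 5.7 nM

Going by the values given here, in an in vitro assay on 293-EBNA cells for binding affinity to corticotropin-releasing factor receptor 1 (Homo sapiens) (on this read-out higher numbers stand for weaker inhibition and lower numbers for stronger inhibition), compound 2 gives 5.7 nM, the lowest of the two numbers, while compound 1 gives 65 nM, a gap beyond the scatter; the two structures differ in more than one place, so no single step joins them. Compound 3 `CCCC(CCC)Nc1nc(C)nc2c1nnn2-c1c(C)cc(C)cc1C` is not yet measured. It differs from compound 2 by 1-propylbutyl in place of pentan-3-yl on a nitrogen on an aromatic ring. For compound 3 the expected step in this assay is a 1.1-fold higher number from compound 2 to compound 3 (0.06 log units; within the scatter), not beyond the scatter. Compound 3 is therefore estimated at 6.5 nM, within 2.2 nM to 20 nM.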

Compound 3, inhibition constant: 4 nM
Beside the measured number, compound 3's estimate is 1.6-fold (0.21 log units) above it, and the stated range covers the measured number.
By their numbers in this assay, from the lowest: compounds 3 and 2 (each within the scatter of the next); then compound 1.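

In this assay, 1-propylbutyl in place of pentan-3-yl on a nitrogen on an aromatic ring gives a 1.4-fold lower number from compound 2 to compound 3 (0.15 log units; within the scatter). Going by these compounds alone, this is the first comparison of compounds that differ in one place, and it shows that this position accepts a group of 7 heavy atoms in place of one of 5 heavy atoms with no change beyond the scatter.

As far as these compounds go, whether that tolerance extends to a longer chain, a cyclopentyl ring or a chain carrying an ether oxygen on this nitrogen remains open. Nothing available explains why this change leaves the read-out within the scatter.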